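Enlarging the alkyl group on the hydrazine nitrogen

The compounds below may be only part of what the source reports. "The series", "measured", "known", "first", "only" and "open" are said of these compounds alone.

Three compounds share one core and differ only in the substituent pattern on the hydrazine arm. Compound 1 `Cc1ccccc1-c1nnc(N(C)N)s1` gives 75 mg/kg in a functional assay on the whole organism with Mus musculus as the target, in the maximal electroshock model, with a stated time of 1 h; on this read-out higher numbers stand for an effect only at larger amounts of compound and lower numbers for an effect already at smaller amounts. Compound 2 `Cc1ccccc1-c1nnc(N(N)C(C)C)s1` gives 54 mg/kg in this assay. Compound 3 `CNNc1nnc(-c2ccccc2C)s1` reaches only a limit of the assay, > 100 mg/kg, and so its place is known only as a boundary, not as a number; it sits at the limit of > 100 mg/kg in this assay, at which 1 of the 3 values shown sits.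

The unmeasured compound 4 `Cc1ccccc1-c1nnc(NNC2CCCC2)s1` arises from compound 3 by cyclopentyl in place of methyl on an amine nitrogen. The closest measured step is the enlargement of methyl to isopropyl on a nitrogen, a 1.4-fold lower number from compound 1 to compound 2 (0.14 log units; within the scatter), which stays within the scatter. The steps of an at least 1.3-fold higher number from compound 1 to compound 3 (0.12 log units; that floor lies within the scatter) and an at least 1.8-fold higher number from compound 2 to compound 3 (0.26 log units; that floor lies within the scatter) only set floors, because compound 3 stands at a limit.

A larger alkyl group on this nitrogen is therefore expected to change little, and compound 4 is estimated at 110 mg/kg, within 50 mg/kg to 300 mg/kg, which means an expected step that the limit leaves unreadable from compound 3 to compound 4 in this assay; a further limit rather than a number is quite possible.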

Compound 4, dose for half-maximal effect: > 100 mg/kg
Compound 4: a limit, no number (the forecaster's own chance of this, stated with the estimate: 55%); the middle value is on the limit's open side.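

For the compounds shown here, compound 3 and compound 4 both stand at a limit in this assay rather than at a number, so no step between them can be read: the limit of > 100 mg/kg in this assay, at which 2 of the 4 values shown sit. The compounds shown leave open whether cyclopentyl in place of methyl on this amine nitrogen changes the dose needed at all, and by how much.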